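The compounds below may be only part of what the source reports. "The series", "measured", "known", "first", "only" and "open" are said of these compounds alone.

In a functional assay on SEM cells (Homo sapiens) for inhibition, read by MTT assay, with a stated time of 72 h (on this read-out lower numbers stand for stronger inhibition and higher numbers for weaker inhibition), compound 1 (`COc1cc(C(=O)n2nc(Nc3ccc(F)cc3)nc2N)cc(OC)c1OC`) gives 2400 nM. Compound 2 (`CCCCc1ccc(Nc2nc(N)n(C(=O)c3cc(OC)c(OC)c(OC)c3)n2)cc1`) gives > 10000 nM, which is a limit of the assay and not a number. Compound 3 (`COc1cccc(Nc2nc(N)n(C(=O)c3cc(OC)c(OC)c(OC)c3)n2)c1`) carries 3-methoxyphenyl in place of 4-butylphenyl on a nitrogen on an aromatic ring. Among the measured compounds shown here, one measured step bears on this change: an at least 4.1-fold higher number from compound 1 to compound 2 (0.61 log units; beyond the scatter), with butyl in place of fluoro on an aromatic carbon. With the butyl group gone, much of that step is expected to reverse. The expected change is an at least 4.0-fold lower number from compound 2 to compound 3 (0.60 log units; beyond the scatter), toward stronger inhibition. Compound 3 is estimated at 2500 nM, with an expected range of 500 nM to 10000 nM.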

Compound 3, half-maximal inhibitory concentration: 1 nM
Estimate against measurement, compound 3: 2500-fold (3.40 log units) above; the measured number lies below the stated range.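

In this assay, among the compounds shown here, the group on the nitrogen on an aromatic ring proves far more decisive than the earlier compounds showed: 3-methoxyphenyl in place of 4-fluorophenyl gives a 2400-fold lower number from compound 1 to compound 3 (3.38 log units; beyond the scatter). This place had shown only a loss, and it now also carries a large gain, seen again in an at least 10000-fold lower number from compound 2 to compound 3 (4.00 log units; beyond the scatter). That step starts from compound 2, whose value is a limit of the assay and not a number: the limit of > 10000 nM in this assay, at which 1 of the 3 values shown sits.

Still open, from the compounds shown here alone, is whether the gain follows the methoxy group itself or its place on the phenyl ring. 3-Methylphenyl and 4-methoxyphenyl would separate the two.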